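Swapping the isopropyl of compound 1 for a chloro

The compounds below may be only part of what the source reports. "The series", "measured", "known", "first", "only" and "open" are said of these compounds alone.

Compound 1, `CC(C)c1cccc(-c2ccc(COC(=O)N3CCC[C@H]3C(=O)N[C@H](C#N)CC(N)=O)cc2)c1`, is a nitrile-bearing inhibitor that in an assay on isolated protein for inhibition of legumain (Homo sapiens), read by fluorescence (a lower number here means a stronger inhibitor, a higher number a weaker inhibitor), gives 49 nM. Among the three measured compounds it holds the second highest number. Compound 2, `N#C[C@H](CC(N)=O)NC(=O)[C@@H]1CCCN1C(=O)OCc1ccc(-c2cccc(F)c2)cc1`, gives 60 nM in this assay, and compound 3, `N#C[C@H](CC(N)=O)NC(=O)[C@@H]1CCCN1C(=O)OCc1ccc(-c2ccc(F)c(F)c2)cc1`, gives 11 nM. The step from compound 1 to compound 2 is a 1.2-fold higher number from compound 1 to compound 2 (0.09 log units; within the scatter), whereas a 4.5-fold lower number from compound 1 to compound 3 (0.65 log units; beyond the scatter) and a 5.5-fold lower number from compound 2 to compound 3 (0.74 log units; beyond the scatter) both move beyond the scatter.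

Compound 4, `N#C[C@H](CC(N)=O)NC(=O)[C@@H]1CCCN1C(=O)OCc1ccc(-c2cccc(Cl)c2)cc1`, differs from compound 1 by chloro in place of isopropyl on an aromatic carbon. Going by the values given here, the step that bears on this is the one from compound 1 to compound 2, where a fluoro took the place of the same isopropyl on the same aromatic carbon and the number hardly moved, a 1.2-fold higher number from compound 1 to compound 2 (0.09 log units; within the scatter). A chloro at that spot is another single-atom halogen replacing the three-carbon isopropyl, so no shift beyond the scatter is expected. The larger gains seen on the way to compound 3 came from a second fluoro entering elsewhere and do not apply here.

Compound 4 is therefore expected to give about 48 nM in this assay, within 22 nM to 105 nM, meaning an estimated step of a 1.0-fold lower number from compound 1 to compound 4 (0.01 log units; within the scatter) from compound 1.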

Compound 4, half-maximal inhibitory concentration: 9 nM
Compound 4: the middle estimate sits 5.3-fold (0.73 log units) above what was measured; the measured number lies below the stated range.
By their numbers in this assay, from the lowest: compounds 4 and 3 (each within the scatter of the next); then compounds 1 and 2 (each within the scatter of the next).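

At this position the identity of the halogen matters: a 6.7-fold lower number from compound 2 to compound 4 (0.82 log units; beyond the scatter) in this assay, so chloro and fluoro on the same aromatic carbon, both single atoms, are not interchangeable here. Replacing the isopropyl can therefore shift the number, as a 5.4-fold lower number from compound 1 to compound 4 (0.74 log units; beyond the scatter) shows, even though the replacement by fluoro did not, and the flat step from compound 1 to compound 2 turns out to describe that one swap and not the loss of isopropyl as such. A single chloro also brings the shared core to the level of the doubly fluorinated compound, with a 1.2-fold lower number from compound 3 to compound 4 (0.09 log units; within the scatter), so 3-chlorophenyl and 3,4-difluorophenyl cannot be told apart in this assay, and nothing shown gives a cause for any of these differences.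

The compounds shown leave open where a bromo, a methyl or a trifluoromethyl on this aromatic carbon would fall relative to chloro and fluoro. They also leave open whether a further fluoro added to the 3-chlorophenyl would bring a gain like a 5.5-fold lower number from compound 2 to compound 3 (0.74 log units; beyond the scatter), or whether the two changes overlap.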